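The source may report more compounds than this note shows. Statements on the series, on what has been measured and on what is new or still open speak of the compounds shown alone.

In a functional assay on Huh-7 cells (Homo sapiens) for cytotoxicity, read by MTT assay, with a stated time of 72 h (a higher number here means that more compound is tolerated, a lower number that less compound is tolerated), compound 1 `CCS(=O)(=O)N1CCC2(CC1)OOC1(CCCC1)OO2` gives > 100 ug/mL as its result, and this is a limit of the assay, not a number. Compound 2 `CCCS(=O)(=O)N1CCC2(CC1)OOC1(CCCCCC1)OO2` gives > 100 ug/mL and this too is a limit. Going by the values given here, the only footing is therefore the limit of > 100 ug/mL in this assay, at which 2 of the 2 values shown sit, with no measured step to scale from. Compound 3 `O=S(=O)(c1ccc(Br)cc1F)N1CCC2(CC1)OOC1(CCCC1)OO2` differs from compound 1 by 4-bromo-2-fluorophenyl in place of ethyl on a sulfonyl sulfur on the shared core, that is, 4-bromo-2-fluorophenyl in place of ethyl on a sulfonyl sulfur. In this assay the expectation is a modest move toward less compound tolerated, possibly none beyond the scatter. The estimated shift is an at least 1.1-fold lower number from compound 1 to compound 3 (0.04 log units; that floor lies within the scatter) and it remains loose, as the starting point is only a limit. Compound 3 is expected at 90 ug/mL with an estimated range from 30 ug/mL to 200 ug/mL and a real chance of only a limit.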

Compound 3, half-maximal cytotoxic concentration: > 100 ug/mL
Compound 3 ended at the assay's limit; the forecaster's own chance of this, stated with the estimate: 55%; at least 1.1-fold (0.04 log units) between middle value and limit.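

No step can be read from compound 1 to compound 3 in this assay, as both results are limits of the assay: the limit of > 100 ug/mL in this assay, at which 3 of the 3 values shown sit.

Still open, going by these compounds, is where any of the three compounds lies past that limit, and whether 4-bromo-2-fluorophenyl in place of ethyl on a sulfonyl sulfur changes the result at all.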